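A few compounds are considered here, and "the series" means these few. Any claim that something is new, unique, unknown or untested is made for them only; others in the source may bear on it.

Measured so far:
- compound 1 `COc1cc(C)cc(-c2nn(CC#N)cc2-c2ccc(-c3cccc(C(C)=O)c3)nc2)c1`: 81%
- compound 2 `Cc1cc(O)cc(-c2nn(CC#N)cc2-c2ccnc(-c3ccc(Oc4ccccc4)cc3)c2)c1`: 107%
- compound 3 `COc1cc(C)cc(-c2nn(CC#N)cc2-c2ccnc(-c3ccc(N(C)C)cc3)c2)c1`: 20%

Three compounds share a common core and differ in the ring that hangs off it and in the group on one of the outer rings. They were tested in a functional assay on HCC 2998 cells (Homo sapiens) for cytotoxicity, read by sulforhodamine B assay, with a stated time of 48 h, tested at 100 nM; on this read-out higher numbers stand for a weaker effect at the one concentration tested and lower numbers for a stronger effect. Compound 3 stands lowest of the three numbers, which on this read-out means the strongest effect. The nearest to it is compound 1, whose number is higher by an amount beyond the scatter; compound 2 lies furthest away, again beyond the scatter.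

The next compound, compound 4 `Cc1cc(O)cc(-c2nn(CC#N)cc2-c2ccnc(-c3ccc(N(C)C)cc3)c2)c1`, has not yet been measured. It differs from compound 3 in one place: hydrogen in place of methyl on an oxygen on an aromatic ring. Among the measured compounds shown here, compound 2 also carries a hydroxy group, and compound 1 a methoxy group, but each of them also differs elsewhere, so neither pair shows this single change on its own, and no measured step for it exists.

For the measured compounds named here, with no such step to lean on, only a modest change is expected, and its direction is uncertain; the step from compound 3 to compound 4 is estimated as a number 15 percentage points higher from compound 3 to compound 4 (beyond the scatter) in this assay. For compound 4 the expected result is 35%, in a range from 10% to 75%.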

Compound 4, a percentage reported as activity, at one concentration (the size of the read-out at that concentration, not a potency): 87%
Compound 4: the middle estimate sits 52 percentage points below what was measured, outside the stated range (above it).
By their numbers in this assay, from the lowest: compound 3; then compounds 1 and 4 (each within the scatter of the next); then compound 2.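

In this assay, changing methoxy to hydroxy with everything else held the same gives a number 67 percentage points higher from compound 3 to compound 4 (beyond the scatter) and is a large step, so the methyl on this oxygen counts for much of the strong effect seen at this single concentration. With the hydroxy group kept, dimethylamino in place of phenoxy gives only a number 20 percentage points lower from compound 2 to compound 4 (beyond the scatter) and is a modest step, so the dimethylamino group that compound 3 also carries does not, on its own, bring the number of a hydroxy compound down to a low level. Nothing available explains why removing this methyl weakens the effect so much.

As far as these compounds go, whether a longer chain on the oxygen, such as ethoxy, or a fluorine in place of the whole oxygen group would keep the low number of compound 3 remains open. Also open is whether the change from methoxy to hydroxy is just as large when phenoxy stands in place of dimethylamino, and, with only one concentration tested, how the strength of the effect of these compounds would compare at other concentrations.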